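A few compounds are considered here, and "the series" means these few. Any claim that something is new, unique, unknown or untested is made for them only; others in the source may bear on it.

Of the compounds shown here, two have been measured in an assay on CHO cells for displacement of a labelled ligand from adenosine receptor A1 (Homo sapiens), read by scintillation counting; on this read-out lower numbers stand for stronger inhibition and higher numbers for weaker inhibition. Compound 1 `Nc1nc(CCc2ccc(O)cc2)nc2cn(-c3ccccc3)nc12` gives 420 nM, and compound 2 `COc1ccc(CCCc2nc(N)c3nn(-c4ccccc4)cc3n2)cc1` gives 16 nM. Within the data shown here, the one recorded step, a 26-fold lower number from compound 1 to compound 2 (1.42 log units; beyond the scatter), came with 4-methoxybenzyl in place of 4-hydroxyphenyl on a saturated chain carbon, two bonds along the chain from an aromatic carbon. Compound 2 therefore holds the lowest of the two numbers. Compound 3 `Nc1nc(CCCc2ccccc2O)nc2cn(-c3ccccc3)nc12` is not yet measured; it differs from compound 2 by 2-hydroxyphenyl in place of 4-methoxyphenyl on a saturated chain carbon, three bonds along the chain from an aromatic carbon. Among the measured compounds shown here, only the step from compound 1 to compound 2 bears on this change, and it mixes a longer chain with a switch from hydroxy to methoxy, so it cannot be read cleanly. A return from methoxy to hydroxy with the chain kept is expected to weaken binding somewhat. Compound 3 is estimated at 80 nM, with a range from 25 nM to 300 nM. The step expected is a 5.0-fold higher number from compound 2 to compound 3 (0.70 log units; beyond the scatter).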

Compound 3, inhibition constant: 0.54 nM
Compound 3: the middle estimate sits 150-fold (2.17 log units) above what was measured, and the stated range ends above it.
By their numbers in this assay, from the lowest: compound 3; then compound 2; then compound 1.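

In this assay, the change shows that 2-hydroxyphenyl at the end of this chain can give much stronger inhibition than 4-methoxyphenyl, with a 30-fold lower number from compound 2 to compound 3 (1.47 log units; beyond the scatter) as the measured step, so a hydroxy group on the ring need not weaken binding here. Among these compounds, the comparison with the shorter hydroxy compound gives a 780-fold lower number from compound 1 to compound 3 (2.89 log units; beyond the scatter), the largest step so far, though it mixes a longer chain with a moved hydroxy group and cannot be divided between them. Nothing available explains why the number falls so far.

From the compounds shown here alone, it remains open whether the drop belongs to the hydroxy group itself or to where it sits on the ring, which 4-hydroxyphenyl or 2-methoxyphenyl on the same chain would help separate. Also open, going by these compounds, is how an amine or a carboxylic acid in place of the hydroxy group, or a still longer chain, would read.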